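Swapping Dimethylamino for Methyl on an Inactive Core

A few compounds are considered here, and "the series" means these few. Any claim that something is new, unique, unknown or untested is made for them only; others in the source may bear on it.

Measured in a functional assay on T47D cells (Homo sapiens) for cytotoxicity, read by MTT assay, with a stated time of 2 days; a higher number here means a weaker inhibitor, a lower number a stronger inhibitor:
- Compound 1 `CN(C)c1ccc2nc(-c3cccc4ccccc34)[nH]c(=O)c2c1`: > 50000 nM (a limit)
- Compound 2 `Cc1ccc2nc(-c3ccccc3C)[nH]c(=O)c2c1`: > 50000 nM (a limit)

Compound 1 reads > 50000 nM, which is a limit of the assay and not a number. Compound 2 reads > 50000 nM, which is also a limit. The whole measured set thus comes down to the limit of > 50000 nM in this assay, at which 2 of the 2 values shown sit, so neither compound has a numerical position.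

Compound 3 `Cc1ccc2nc(-c3cccc4ccccc34)[nH]c(=O)c2c1` keeps the core of compound 1 and carries methyl in place of dimethylamino on an aromatic carbon, meta to a fused ring and para to a fused ring: methyl in place of dimethylamino on an aromatic carbon. Among the measured compounds shown here, no measured pair isolates this change, so the data do not show its size. In this assay, at most a modest shift towards stronger inhibition is expected, and a result beyond the scatter would be a surprise. The estimated change is an at least 1.2-fold lower number from compound 1 to compound 3 (0.09 log units; that floor lies within the scatter). A further report of only a limit is quite possible. Compound 3 is estimated at 40000 nM, with an expected range from 8000 nM to 80000 nM.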

Compound 3, half-maximal inhibitory concentration: > 50000 nM
Compound 3: a limit, no number; the forecaster's own chance of this, stated with the estimate: 60%; at least 1.2-fold (0.09 log units) between middle value and limit.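

In this assay compound 3 gives > 50000 nM, which is a limit of the assay and not a number. Compound 1 also stands at a limit, so no size can be read for the change from compound 1 to compound 3: the limit of > 50000 nM in this assay, at which 3 of the 3 values shown sit.

The compounds shown leave open where compound 1, compound 2 or compound 3 would stand as a number in this assay.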